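The compounds below may be only part of what the source reports. "The series", "measured", "known", "first", "only" and "open" are said of these compounds alone.

Measured so far in an ADME assay on HepG2 cells (Homo sapiens) for cytotoxicity, in the presence of a further agent that is not named here; a higher number here means a weaker inhibitor, a lower number a stronger inhibitor

compound 1 `Cn1c(Cc2ccccc2)nc(C(=O)NCc2ccccc2)c(O)c1=O` gives > 100000 nM
compound 2 `Cn1c(Cc2ccccc2C(F)(F)F)nc(C(=O)NCC2CCCCC2)c(O)c1=O` gives > 100000 nM
compound 3 `Cc1nc(C(=O)NCc2ccccc2)c(O)c(=O)n1C` gives > 100000 nM

Each of these three entries is a limit of the assay and not a number. Compound 2 stands at > 100000 nM as a limit, so it offers no exact starting point. The whole set looks the same (the limit of > 100000 nM in this assay, at which 3 of the 3 values shown sit).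

Compound 4 `Cn1c(Cc2ccccc2C(F)(F)F)nc(C(=O)NCc2ccccn2)c(O)c1=O` has not yet been measured. It differs from compound 2 in one place: pyridin-2-yl in place of cyclohexyl on a saturated chain carbon bound to an amide-type nitrogen and so pyridin-2-yl stands in place of cyclohexyl on a saturated chain carbon bound to an amide-type nitrogen.

Among the measured compounds shown here, the only measured step is a step that the two limits leave unreadable from compound 1 to compound 3 and it concerns a different change, so it gives no size to carry over. For the measured compounds named here, no measured step touches the place that changes here. With compound 2 at > 100000 nM as the closest relative, no shift beyond the usual scatter is expected, and the result may well be only a limit again. The expected step is a number no higher from compound 2 to compound 4 (the limit leaves the size open) and no direction is expected for it. In this assay the estimate for compound 4 is 100000 nM with an expected range from 50000 nM to 200000 nM as its two ends.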

Compound 4, half-maximal inhibitory concentration: > 100000 nM
Compound 4 ended at the assay's limit; the forecaster's own chance of this, stated with the estimate: 85%; the middle value lies on the limit itself.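

Compound 2 and compound 4 both stand at a limit of the assay and not at a number, so no size or direction can be read for the change from cyclohexyl to pyridin-2-yl. All the compounds shown look alike: the limit of > 100000 nM in this assay, at which 4 of the 4 values shown sit. The compounds shown leave open whether any change to the shared core would move a result in this assay away from this limit.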